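A few compounds are considered here, and "the series" means these few. Any claim that something is new, unique, unknown or untested is made for them only; others in the source may bear on it.

The study concerns four compounds tested in a functional assay on LoVo cells (Homo sapiens) for antiproliferative activity, read by MTT assay, with a stated time of 72 h; on this read-out higher numbers stand for weaker inhibition of growth and lower numbers for stronger inhibition of growth. Compound 1, `COc1cc(OC)n2cc(-c3ccc([N+](=O)[O-])cc3)nc2n1`, carries a nitro group, and in this assay compound 1 gives 70600 nM. Compound 2, `COc1cc(OC)n2cc(-c3ccc(N)cc3)nc2n1`, differs from compound 1 by amino in place of nitro on an aromatic carbon. For compound 2 this assay reports only a limit, > 100000 nM. The change thus produced an at least 1.4-fold higher number from compound 1 to compound 2 (0.15 log units; that floor lies within the scatter).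

Compound 3, `Cc1ccc2nc(-c3ccc([N+](=O)[O-])cc3)cn2c1`, keeps the nitro group but sits on a different core; the difference between the two cores is not broken down here. For compound 3 this assay again reports only a limit, > 100000 nM. This means that two of the three measured values are limits rather than numbers, as stated in the limit of > 100000 nM in this assay, at which 2 of the 3 values shown sit.

Compound 4, `Cc1ccc2nc(-c3ccc(N)cc3)cn2c1`, has not yet been measured. It differs from compound 3 by amino in place of nitro on an aromatic carbon, the same change as that from compound 1 to compound 2, so that this change occurs twice among the compounds shown. The expectation for compound 4 in this assay rests on the step already seen, an at least 1.4-fold higher number from compound 1 to compound 2 (0.15 log units; that floor lies within the scatter), which did not lower the number. It also rests on the starting point of compound 3, whose value > 100000 nM is itself a limit. Compound 4 is therefore expected to give about 150000 nM, with a range from 70000 nM to 400000 nM, most likely reported again as a limit. The step from compound 3 to compound 4 is accordingly estimated at a step that the limit leaves unreadable from compound 3 to compound 4.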

Compound 4, concentration for 50% growth inhibition: 65200 nM
Compound 4: the middle estimate sits 2.3-fold (0.36 log units) above what was measured, and the stated range ends above it.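

On the core of compound 3, amino in place of nitro on an aromatic carbon gives an at least 1.5-fold lower number from compound 3 to compound 4 (0.18 log units; that floor lies within the scatter) in this assay. Set beside the same change on the core of compound 1, the printed steps run in opposite directions, yet neither has a fixed size, and so the comparison between them stays unsettled: the same change on two cores in this assay, an at least 1.4-fold higher number (0.15 log units; that floor lies within the scatter) from compound 1 to compound 2 and an at least 1.5-fold lower number (0.18 log units; that floor lies within the scatter) from compound 3 to compound 4; the limit leaves it open whether they differ The series therefore does not show that this change carries from one core to the other with the same outcome, nor does it show that the outcome depends on the core, since each of the two steps rests on a limit: the limit of > 100000 nM in this assay, at which 2 of the 4 values shown sit.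

The compounds shown leave open whether a group other than nitro or amino at this place on the six-membered aromatic ring, such as a carboxylic acid, a nitrile or an acetamide, would move the number in this assay on either core. They also leave open how the two cores compare with each other on their own, for every pair of compounds that spans the two cores differs in more than one place or includes a limit.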